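This account rests on a few compounds, and the source may have more. Where it says the series, first, only, none or still open, it means among the compounds named here.

Measured compounds:
Compound 1, `C[C@@H]1CN(c2sc(C(F)(F)F)nc2-c2nc3cc(Cl)ccc3[nH]2)CCN1C(=O)Cn1cnc2cccnc21`: 38.5 nM
Compound 2, `Cc1nc(C)n(CC(=O)N2CCN(c3sc(C(F)(F)F)nc3-c3nc4ccccc4[nH]3)C[C@H]2C)n1`: 237 nM
Compound 3, `Cc1nc(C)n(CC(=O)N2CCN(c3sc(C(F)(F)F)nc3-c3nc4ccc(C5CCN(C)CC5)cc4[nH]3)C[C@H]2C)n1`: 84.7 nM

In a functional assay on Venous blood for antagonist activity at C-X-C chemokine receptor type 3 (Homo sapiens), read by flow cytometry, with a stated time of 30 min, in the presence of a further agent that is not named here (on this read-out lower numbers stand for stronger inhibition and higher numbers for weaker inhibition), compound 1 gives the lowest number of the three, so it is the strongest inhibitor in this small set; compound 3 stands closest to it and compound 2 furthest away. Compound 4, `C[C@@H]1CN(c2sc(C(F)(F)F)nc2-c2nc3cc(OCCO)ccc3[nH]2)CCN1C(=O)Cn1cnc2cccnc21`, keeps everything else of compound 1 and changes one spot on the fused ring system: 2-hydroxyethoxy in place of chloro on an aromatic carbon.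

Within the data shown here, only one measured step touches the same kind of place. From compound 2 to compound 3 a substituent was put onto an aromatic carbon of that fused ring system where compound 2 carries only hydrogen, and this gave a 2.8-fold lower number from compound 2 to compound 3 (0.45 log units; beyond the scatter). That step shows this part of the core tolerates an added group, but it adds to hydrogen rather than swapping one group for another, and the group it adds is not the one entering here. Among the measured compounds shown here, no measured pair shows a chloro traded for a 2-hydroxyethoxy chain. The expectation for the change from compound 1 to compound 4 is therefore a small step, most likely towards a somewhat higher number, a 1.7-fold higher number from compound 1 to compound 4 (0.23 log units; within the scatter). Compound 4 is thus estimated at 65 nM, with a range from 25 nM to 170 nM.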

Compound 4, half-maximal inhibitory concentration: 99.1 nM
Beside the measured number, compound 4's estimate is 1.5-fold (0.18 log units) below it; measured number inside the range.
By their numbers in this assay, from the lowest: compound 1; then compounds 3 and 4 (each within the scatter of the next); then compound 2.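

In this assay, among these compounds, 2-hydroxyethoxy in place of chloro on an aromatic carbon gives a 2.6-fold higher number from compound 1 to compound 4 (0.41 log units; beyond the scatter), and this is the first direct trade of one group for another on this part of the core. The step lies beyond the scatter but is modest, so at this place a chain of 4 heavy atoms ending in a hydroxyl group can replace a single chlorine with only a limited loss of inhibition. Nothing available here accounts for that rise in the number.

From the compounds shown here alone, it remains open whether the rise reflects the loss of chloro or the arrival of the chain, a question that plain hydrogen or a small methoxy group at this place on the core of compound 1 could help to settle. Going by these compounds, it is equally open whether a chain of another kind, such as a longer one or one ending in an amine or a carboxylic acid, would move the number further up or bring it back down.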